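From methyl to tert-butyl: how far will compound 4 move?

This account rests on a few compounds, and the source may have more. Where it says the series, first, only, none or still open, it means among the compounds named here.

Among the measured compounds shown here, in a functional assay on CCRF-CEM cells (Homo sapiens) for antiproliferative activity, read by MTT assay (a lower number here means a stronger inhibitor, a higher number a weaker inhibitor), compound 1 `C/C(=N\Nc1nc2ccccc2o1)c1ccccn1` gives 15 nM, the lowest number so far. Compound 2 `C/C(=N\Nc1nc2ccccc2o1)c1ncccn1` gives 130 nM. Its pyrimidin-2-yl in place of pyridin-2-yl makes an 8.7-fold higher number from compound 1 to compound 2 (0.94 log units; beyond the scatter), a modest step beyond the scatter. Compound 3 `C/C(=N\N(C)c1nc2ccccc2o1)c1ccccn1` reads > 50000 nM, which is a limit of the assay and not a number. Methyl in place of hydrogen on a nitrogen on an aromatic ring thus makes an at least 3300-fold higher number from compound 1 to compound 3 (3.52 log units; beyond the scatter), a large step.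

Compound 4 `CC(C)(C)/C(=N\Nc1nc2ccccc2o1)c1ccccn1` has not been measured. It carries tert-butyl in place of methyl on a carbon with a double bond to nitrogen. Neither measured step touches this place, so both guide the estimate only loosely. Both went upward, and the smaller was an 8.7-fold higher number from compound 1 to compound 2 (0.94 log units; beyond the scatter). In this assay a modest upward move is therefore expected, a 3.3-fold higher number from compound 1 to compound 4 (0.52 log units; beyond the scatter), though a result within the scatter would be no surprise. Compound 4 is estimated at 50 nM, with an expected range of 8 nM to 400 nM.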

Compound 4, half-maximal inhibitory concentration: > 10000 nM
Compound 4 was reported as a limit; the forecaster's own chance of this, stated with the estimate: 4%; middle value at least 200-fold (2.30 log units) from the limit.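

Compound 2 and compound 3 left the carbon with a double bond to nitrogen untouched, so compound 4 gives the first view of how much that place matters. In this assay, tert-butyl in place of methyl there makes an at least 660-fold higher number from compound 1 to compound 4 (2.82 log units; beyond the scatter), a large step, so the low number of compound 1 does not survive this change. The reading of compound 4 is a limit of the assay and not a number, so the step has a floor but no known end: the limit of > 10000 nM in this assay, at which 1 of the 4 values shown sits.

With only methyl and tert-butyl shown at this place, it remains open whether ethyl or isopropyl would keep a number close to that of compound 1 or would already raise it. The compounds shown also cannot tell what about tert-butyl produces this step.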